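A few compounds are considered here, and "the series" means these few. Any claim that something is new, unique, unknown or untested is made for them only; others in the source may bear on it.

Three measured compounds share one core and differ only in the aryl group on the ring nitrogen. In an ADME assay on HT-29 cells (Homo sapiens) for cytotoxicity, read by MTT assay, with a stated time of 72 h (a lower number here means a stronger inhibitor, a higher number a weaker inhibitor), compound 1 `C=CC(=O)Nc1cc(Nc2ncc3ncn(-c4ccc(C)cc4)c3n2)c(OC)cc1N(C)CCN(C)C` gives 9230 nM, compound 2 `C=CC(=O)Nc1cc(Nc2ncc3ncn(-c4ccc(CC)cc4)c3n2)c(OC)cc1N(C)CCN(C)C` gives 8180 nM, and compound 3 `C=CC(=O)Nc1cc(Nc2ncc3ncn(-c4ccc(F)cc4)c3n2)c(OC)cc1N(C)CCN(C)C` gives 12000 nM. Compound 3 sits alongside the other two: a 1.3-fold higher number from compound 1 to compound 3 (0.11 log units; within the scatter) and a 1.5-fold higher number from compound 2 to compound 3 (0.17 log units; within the scatter), so the three numbers are indistinguishable here. Compound 4 `C=CC(=O)Nc1cc(Nc2ncc3ncn(-c4ccccc4F)c3n2)c(OC)cc1N(C)CCN(C)C` is unmeasured; it differs from compound 3 by 2-fluorophenyl in place of 4-fluorophenyl on an aromatic nitrogen. Going by the values given here, no measured step moves the fluorine within the ring; the measured steps only exchange groups at one site and all stay within the scatter, as does a 1.1-fold lower number from compound 1 to compound 2 (0.05 log units; within the scatter). No step beyond the scatter is therefore expected in this assay. Compound 4 is estimated at 11500 nM, range 5500 nM to 24000 nM, a step of a 1.0-fold lower number from compound 3 to compound 4 (0.02 log units; within the scatter).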

Compound 4, half-maximal inhibitory concentration: 9750 nM
The estimate for compound 4 lay 1.2-fold (0.07 log units) above the measured number; the range from low to high includes it.
By their numbers in this assay, from the lowest: compounds 2, 1, 4 and 3 (each within the scatter of the next).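

In this assay, moving the fluorine within the ring at this site gives a 1.2-fold lower number from compound 3 to compound 4 (0.09 log units; within the scatter), so this position has now been tested for fluorine placement as well as for exchange of the group, and the change stays within the scatter. The 2-fluorophenyl group also stays within the scatter of the alkyl-substituted aryl groups, at a 1.2-fold higher number from compound 2 to compound 4 (0.08 log units; within the scatter) and a 1.1-fold higher number from compound 1 to compound 4 (0.02 log units; within the scatter). No supporting data bear on this result.

On these data alone, whether an amine or a carboxylic acid on the aryl ring would give a step beyond the scatter in this assay remains open. The same applies to a longer chain at that site.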